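Chain extension from compound 3 to compound 4

The source may hold more compounds than are shown below. What is called first, only, known or untested is meant among the compounds shown, and "the series" means these compounds.

Compound 1 `COc1cc2c(Nc3ccc(F)c(Cl)c3)ncnc2cc1OCCCCCCn1ccnc1[N+](=O)[O-]`: 13400 nM
Compound 2 `COc1cc2c(Nc3cccc(Br)c3)ncnc2cc1OCCCn1ccnc1[N+](=O)[O-]`: 13500 nM
Compound 3 `COc1cc2c(Nc3cccc(Br)c3)ncnc2cc1OCCCCCn1ccnc1[N+](=O)[O-]`: 8780 nM

In a functional assay on A549 cells (Homo sapiens) for inhibition, read by sulforhodamine B assay, with a stated time of 72 h (a higher number here means a weaker inhibitor, a lower number a stronger inhibitor), compound 3, at 8780 nM, lies within the scatter of both compound 1 and compound 2. Compound 4 `COc1cc2c(Nc3cccc(Br)c3)ncnc2cc1OCCCCCCn1ccnc1[N+](=O)[O-]` is still unmeasured, and its structure departs from that of compound 3 as follows: (2-nitro-1H-imidazol-1-yl)methyl in place of 2-nitro-1H-imidazol-1-yl on a saturated chain carbon, five bonds along the chain from an oxygen on an aromatic ring. Among the measured compounds shown here, the only measured step that lengthens the chain is a 1.5-fold lower number from compound 2 to compound 3 (0.19 log units; within the scatter). Compound 4 also shares its chain with compound 1, which gives 13400 nM, although the two differ elsewhere. No change beyond the scatter is therefore expected in this assay. The expected change is a 1.2-fold higher number from compound 3 to compound 4 (0.08 log units; within the scatter). For compound 4 the estimated value is 10500 nM, with an expected range of 5000 nM to 20000 nM.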

Compound 4, half-maximal inhibitory concentration: 30200 nM
The estimate for compound 4 lay 2.9-fold (0.46 log units) below the measured number; measured number above the stated range.
By their numbers in this assay, from the lowest: compounds 3, 1 and 2 (each within the scatter of the next); then compound 4.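

In this assay the chain change, (2-nitro-1H-imidazol-1-yl)methyl in place of 2-nitro-1H-imidazol-1-yl, now shows a 3.4-fold higher number from compound 3 to compound 4 (0.54 log units; beyond the scatter) and so passes the scatter, which a 1.5-fold lower number from compound 2 to compound 3 (0.19 log units; within the scatter) did not. Compound 4 also stands apart from the shorter chain in a 2.2-fold higher number from compound 2 to compound 4 (0.35 log units; beyond the scatter) and, with 3-bromophenyl in place of 3-chloro-4-fluorophenyl, in a 2.3-fold higher number from compound 1 to compound 4 (0.35 log units; beyond the scatter) on a shared chain. No available evidence accounts for these steps.

From the compounds shown here alone, whether a longer chain would raise the number further remains open. So does the effect of an amine in place of 2-nitro-1H-imidazol-1-yl.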